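Methylating the thiol of compound 2

The compounds below may be only part of what the source reports. "The series", "measured", "known", "first", "only" and "open" are said of these compounds alone.

Going by the values given here, compound 2 `CC(C)C(Sc1nc(S)c2cnn(-c3ccccc3)c2n1)C(N)=O` stands highest of the two numbers known here. In an assay for displacement of a labelled ligand from adenosine receptor A1 (Rattus norvegicus) (on this read-out lower numbers stand for stronger inhibition and higher numbers for weaker inhibition), compound 2 gives 256 nM, whereas compound 1 `CCCC(Sc1nc(SC)c2cnn(-c3ccccc3)c2n1)C(N)=O` gives 7.55 nM, a gap beyond the scatter. Compound 3 `CSc1nc(SC(C(N)=O)C(C)C)nc2c1cnn2-c1ccccc1` is not yet measured; it differs from compound 2 by methyl in place of hydrogen on a sulfur. Since compound 1 gives 7.55 nM while carrying a methylated sulfur, a marked step toward stronger binding is expected a 21-fold lower number from compound 2 to compound 3 (1.33 log units; beyond the scatter). Compound 3 is therefore estimated at 12 nM, within a range of 3 nM to 50 nM.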

Compound 3, inhibition constant: 15.7 nM
For compound 3 the middle estimate is 1.3-fold (0.12 log units) below the measured one, within the range that was stated.
By their numbers in this assay, from the lowest: compound 1; then compound 3; then compound 2.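

In this assay, methyl in place of hydrogen on the sulfur brings a 16-fold lower number from compound 2 to compound 3 (1.21 log units; beyond the scatter) and so marks this sulfur as a place where a single small group matters greatly. Isopropyl in place of propyl on the saturated chain carbon brings only a 2.1-fold higher number from compound 1 to compound 3 (0.32 log units; beyond the scatter) and stands as a modest step, though beyond the scatter. Nothing available here explains why the methyl has this effect. Still open, as far as these compounds go, is how an ethyl or a longer chain on that sulfur would compare, or an amine in place of the methylsulfanyl group.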